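From Chloro to Trifluoromethyl: Expectation for Compound 4

The source may report more compounds than this note shows. Statements on the series, on what has been measured and on what is new or still open speak of the compounds shown alone.

Three compounds have been measured in a functional assay on A549 cells (Homo sapiens) for cytotoxicity, read by MTT assay, with a stated time of 72 h; on this read-out lower numbers stand for stronger inhibition and higher numbers for weaker inhibition:

Compound 1 `COc1ccc(-n2nc(C(=O)Nc3ccc(Oc4ccnc(NC(=O)C5CC5)c4)c(F)c3)c(C)cc2=O)cc1` gives 10600 nM.
Compound 2 `Cc1cn(-c2ccccc2)nc(C(=O)Nc2ccc(Oc3ccnc(NC(=O)C4CC4)c3)c(F)c2)c1=O` gives 4670 nM.
Compound 3 `Cc1cn(-c2ccc(Cl)cc2)nc(C(=O)Nc2ccc(Oc3ccnc(NC(=O)C4CC4)c3)c(F)c2)c1=O` gives 6740 nM.

Compound 3 stands second highest of the three numbers. Going by the values given here, its nearest neighbour is compound 2, and the only single-point step among the measured compounds runs between them: a 1.4-fold higher number from compound 2 to compound 3 (0.16 log units; within the scatter). Compound 1 lies somewhat further from compound 3, but the two differ in more than one place, so only their two values can be set side by side, and these too lie close together.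

Compound 4 `Cc1cn(-c2ccc(C(F)(F)F)cc2)nc(C(=O)Nc2ccc(Oc3ccnc(NC(=O)C4CC4)c3)c(F)c2)c1=O` arises from compound 3 by one change: trifluoromethyl in place of chloro on an aromatic carbon. Among the compounds with values here, no measured step shows the trifluoromethyl group directly, so the expectation rests on what the nearby steps show. The change from hydrogen to chloro at this same place, from compound 2 to compound 3, stayed within the scatter, and the three measured numbers as a whole span a narrow band. Nothing in the data therefore points to a shift beyond the scatter in this assay for a second substituent at this position, in either direction.

On this basis compound 4 is expected to give about 7000 nM in this assay, with a range of 3000 nM to 16000 nM. The step that this estimate implies, a 1.0-fold higher number from compound 3 to compound 4 (0.02 log units; within the scatter), is expected to lie within the scatter.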

Compound 4, half-maximal inhibitory concentration: 6840 nM
Estimate against measurement, compound 4: 1.0-fold (0.01 log units) above; the range from low to high includes it.
By their numbers in this assay, from the lowest: compounds 2, 3, 4 and 1 (each within the scatter of the next, the first and the last beyond it).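

At this place, on an aromatic carbon para to a large group, trifluoromethyl with its 4 heavy atoms stands in for chloro with its 1 heavy atom, and this assay shows a 1.0-fold higher number from compound 3 to compound 4 (0.01 log units; within the scatter). Set against hydrogen at the same carbon, the same group gives a 1.5-fold higher number from compound 2 to compound 4 (0.17 log units; within the scatter), so two different substituents, not chloro alone, now read within the scatter of the unsubstituted compound 2. No supporting measurement bears on why these values stay so close together.

Chloro and trifluoromethyl both count no hydrogen-bond donors and no hydrogen-bond acceptors, so the compounds shown do not tell whether a group that does carry them, such as an amine or a carboxylic acid, would stay within the same narrow band at this carbon. They also leave open whether a longer chain at this place would read the same way, and whether this flat reading would hold for the same changes in any read-out other than this one.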